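A few compounds are considered here, and "the series" means these few. Any claim that something is new, unique, unknown or untested is made for them only; others in the source may bear on it.

Measured compounds:
compound 1 `O=C(Nc1ccc(Oc2ccnc3[nH]ccc23)cc1)c1ccc(-c2ccc(F)cc2F)cn1` — > 10000 nM
compound 2 `Cc1ccc(-c2ccnc(C(=O)Nc3ccc(Oc4ccnc5[nH]ccc45)cc3)c2)cc1` — > 10000 nM

In a functional assay on A549 cells (Homo sapiens) for cytotoxicity, read by MTT assay, with a stated time of 72 h (on this read-out lower numbers stand for stronger inhibition and higher numbers for weaker inhibition), compound 1 gives only a limit, > 10000 nM. In this assay compound 2 likewise gives only a limit, > 10000 nM. Both values sit at the limit of > 10000 nM in this assay, at which 2 of the 2 values shown sit, so compound 2 stands at the same limit as the other value shown. Compound 3 `O=C(Nc1ccc(Oc2ccnc3[nH]ccc23)cc1)c1cc(-c2ccc(Cl)cc2)ccn1` differs from compound 2 by chloro in place of methyl on an aromatic carbon, 4-methylphenyl to 4-chlorophenyl. Among the measured compounds shown here, no measured step covers this change. With both values at the limit, the expected step that the limit leaves unreadable from compound 2 to compound 3 in this assay is none beyond the scatter. For compound 3 the estimate in this assay is 15000 nM, range 5000 nM to 50000 nM, most likely again reported only as a limit.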

Compound 3, half-maximal inhibitory concentration: 4310 nM
The estimate for compound 3 lay 3.5-fold (0.54 log units) above the measured number, outside the stated range (below it).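

In this assay, chloro in place of methyl on an aromatic carbon gives an at least 2.3-fold lower number from compound 2 to compound 3 (0.36 log units; beyond the scatter). This change, para to a large group, is thus enough to bring the series off the limit, which neither earlier compound showed. The full size of the step cannot be read, because compound 2 gives only a limit: the limit of > 10000 nM in this assay, at which 2 of the 3 values shown sit.

On these data alone, what an amine, a carboxylic acid or a bromo group at this carbon would give in this assay stays open. As far as these compounds go, whether chloro gives a similar step on another core also stays open.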